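The source may report more compounds than this note shows. Statements on the series, on what has been measured and on what is new or still open speak of the compounds shown alone.

Compounds measured in an assay on CHO cells for displacement of a labelled ligand from prostaglandin E2 receptor EP3 subtype (Homo sapiens), read by radioligand binding; on this read-out lower numbers stand for stronger inhibition and higher numbers for weaker inhibition:
compound 1 `CC(C)C(Cc1nnc[nH]1)c1ccc(-c2ccc3cccc(F)c3c2)[nH]c1=O` gives 10 nM
compound 2 `CC(C)C(c1ccc(-c2ccc3cccc(F)c3c2)[nH]c1=O)N1CCN/C1=N\C#N` gives 23 nM
compound 3 `CC(C)C(c1cnc(N)s1)c1ccc(-c2ccc3cccc(F)c3c2)[nH]c1=O` gives 16 nM

Compound 3 sits second highest of the three numbers; its gaps to compound 2 and to compound 1 both lie within the scatter, so the three compounds are not separated here. Compound 4 `CC(C)C(Cc1nnn[nH]1)c1ccc(-c2ccc3cccc(F)c3c2)[nH]c1=O` is not yet measured; it carries (1H-tetrazol-5-yl)methyl in place of 2-amino-1,3-thiazol-5-yl on a saturated chain carbon bound to an aromatic carbon and a saturated chain carbon. Among the compounds with values here, the steps that bear on it are a 1.6-fold higher number from compound 1 to compound 3 (0.20 log units; within the scatter) and a 1.4-fold lower number from compound 2 to compound 3 (0.16 log units; within the scatter), both within the scatter, and a 2.3-fold higher number from compound 1 to compound 2 (0.36 log units; beyond the scatter), a modest step. The entering group resembles the (4H-1,2,4-triazol-3-yl)methyl of compound 1 more closely than the leaving group does, so compound 4 is expected to land near compound 1, with the step of a 1.3-fold lower number from compound 3 to compound 4 (0.12 log units; within the scatter) expected to stay within the scatter. Compound 4 is estimated at 12 nM, range 5 nM to 30 nM.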

Compound 4, inhibition constant: 34 nM
The estimate for compound 4 lay 2.8-fold (0.45 log units) below the measured number, outside the stated range (above it).
By their numbers in this assay, from the lowest: compounds 1, 3, 2 and 4 (each within the scatter of the next, the first and the last beyond it).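

With the chain link held and only the ring changed, 1H-tetrazol-5-yl in place of 4H-1,2,4-triazol-3-yl gives a 3.4-fold higher number from compound 1 to compound 4 (0.53 log units; beyond the scatter) in this assay and is the widest step in the series, so this position distinguishes two closely matched rings. The step of a 2.1-fold higher number from compound 3 to compound 4 (0.33 log units; beyond the scatter) is also beyond the scatter, whereas a 1.5-fold higher number from compound 2 to compound 4 (0.17 log units; within the scatter) stays within it, so these two compounds are not separated. No measurement here accounts for the difference between the two rings.

From the compounds shown here alone, it remains open whether a carboxylic acid on the same chain would read closer to compound 1 or to compound 4. Going by these compounds, it is also open whether a longer chain carrying the tetrazole would change the number.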